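The source may report more compounds than this note shows. Statements on the series, on what has been measured and on what is new or still open speak of the compounds shown alone.

Compound 1 `O=C(CSc1nc2c(c(=O)n1-c1ccccc1)SCC2)Nc1ccc(-c2cccs2)cn1` and compound 2 `O=C(CSc1nc2c(c(=O)n1-c1ccccc1)SCC2)Nc1ccc(-c2cccnc2)cn1` share a common core and differ only in the aryl group on an aromatic carbon of the pyridine. In an assay on L cells for inhibition of Protein-serine O-palmitoleoyltransferase porcupine (Mus musculus), read by reporter gene assay, with a stated time of 24 h (on this read-out lower numbers stand for an effect already at smaller amounts and higher numbers for an effect only at larger amounts of compound), compound 1 gives 0.3 nM, and compound 2 gives 1 nM. Going by the values given here, the only measured step, a 3.3-fold higher number from compound 1 to compound 2 (0.52 log units; beyond the scatter), shows that replacing thiophen-2-yl by pyridin-3-yl brought a modest rise in the number. Compound 2 thus stands at the higher of the two numbers measured, with compound 1 the nearer and lower neighbour.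

Compound 3 `O=C(CSc1nc2c(c(=O)n1-c1ccccc1)SCC2)Nc1ccc(-c2cncnc2)cn1` is the next member of this pair: pyrimidin-5-yl in place of pyridin-3-yl on an aromatic carbon. Among the compounds with values here, no measured step covers a pyrimidin-5-yl group; the only step that bears on it is the one from compound 1 to compound 2, which added one ring nitrogen to the aryl group and raised the number modestly. On that basis a further step in the same direction, of roughly similar or somewhat smaller size, is expected from compound 2 to compound 3, a 2.5-fold higher number from compound 2 to compound 3 (0.40 log units; beyond the scatter). Compound 3 is therefore estimated at 2.5 nM in this assay, within a range of 0.8 nM to 8 nM.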

Compound 3, half-maximal effective concentration: 5.5 nM
Beside the measured number, compound 3's estimate is 2.2-fold (0.34 log units) below it; the measured number falls inside the stated range.
By their numbers in this assay, from the lowest: compound 1; then compound 2; then compound 3.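

The step from pyridin-3-yl to pyrimidin-5-yl, a 5.5-fold higher number from compound 2 to compound 3 (0.74 log units; beyond the scatter), shows that this position, on an aromatic carbon para to a large group, still responds when a second ring nitrogen enters a six-membered aromatic ring of the same heavy-atom count, so the change between compound 1 and compound 2 was not the only one here to move the number in this assay. Across the whole series the change from thiophen-2-yl to pyrimidin-5-yl, an 18-fold higher number from compound 1 to compound 3 (1.26 log units; beyond the scatter), is the first large step at this position, and all three compounds fall in one order, with no compound going against it. No measurement given here accounts for this order, so the reason for it remains unexplained.

The three compounds leave open whether the order follows the number of ring nitrogens or the change from a five-membered to a six-membered ring, which a plain phenyl ring or a thiazole on the same carbon would help to separate. They also leave open how a non-aromatic group such as morpholine or a simple amine would fare at this position.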